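The compounds below may be only part of what the source reports. "The series", "measured", "known", "first", "only" and "open" are said of these compounds alone.

Compound 3 `COc1ccc(/C=C/C(=O)/C=C/c2ccc(OCc3cn(CCCCOc4cc(=O)oc5ccccc45)nn3)c(OC)c2)cc1OC` gives 53% in a functional assay on COLO 205 cells (Homo sapiens) for inhibition, read by sulforhodamine B assay, with a stated time of 48 h, tested at 50 uM (a lower number here means less inhibition of growth, a higher number more inhibition of growth at the concentration tested), and stands highest of the three numbers, though compound 1 `COc1cc(/C=C/C(=O)/C=C/c2cccc3ccccc23)ccc1OCc1cn(CCCCOc2cc(=O)oc3ccccc23)nn1`, which gives 50%, and compound 2 `COc1cc(/C=C/C(=O)/C=C/c2ccco2)ccc1OCc1cn(CCCCOc2cc(=O)oc3ccccc23)nn1`, which gives 43%, both lie within the scatter of it. Compound 4 `COc1cc(/C=C/C(=O)/C=C/c2cccs2)ccc1OCc1cn(CCCCOc2cc(=O)oc3ccccc23)nn1` differs from compound 3 as follows: thiophen-2-yl in place of 3,4-dimethoxyphenyl on a double-bonded chain carbon bound to a double-bonded chain carbon. For the measured compounds named here, the steps that bear on this are a number 10 percentage points higher from compound 2 to compound 3 (within the scatter) and a number 3 percentage points higher from compound 1 to compound 3 (within the scatter); neither aryl swap at this position moved the read-out beyond the scatter. Thiophen-2-yl is structurally closest to furan-2-yl, so a small decrease is expected, roughly the size of a number 10 percentage points higher from compound 2 to compound 3 (within the scatter) but in the other direction, still within the scatter. Compound 4 is therefore expected to give 45%, between 35% and 55%, which is a step of a number 8 percentage points lower from compound 3 to compound 4 (within the scatter).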

Compound 4, percent growth inhibition at one concentration: 40%
Compound 4: the middle estimate sits 5 percentage points above what was measured; measured number inside the range.
By their numbers in this assay, from the lowest: compounds 4, 2, 1 and 3 (each within the scatter of the next, the first and the last beyond it).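

For the compounds shown here, with thiophen-2-yl in place of 3,4-dimethoxyphenyl on a double-bonded chain carbon bound to a double-bonded chain carbon, this assay shows a step beyond the scatter, which no earlier step at this position reached (a number 13 percentage points lower from compound 3 to compound 4 (beyond the scatter)). The steps to compound 4 from the other two compounds stay within the scatter (a number 3 percentage points lower from compound 2 to compound 4 (within the scatter); a number 10 percentage points lower from compound 1 to compound 4 (within the scatter)), so thiophen-2-yl is not told apart from furan-2-yl or naphthalen-1-yl. No evidence on hand accounts for the step.

Going by these compounds, whether the step follows the ring itself or its two methoxy groups stays open. So does the read-out with an amine or a carboxylic acid on the phenyl ring at this place.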